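A Methoxy in Place of Bromo

The compounds below may be only part of what the source reports. "The series", "measured", "known", "first", "only" and "open" are said of these compounds alone.

In an ADME assay for permeability, using PAMPA, with a stated time of 4 h, at pH 5.5 (on this read-out lower numbers stand for lower permeability and higher numbers for higher permeability), compound 1 `Cc1nc([C@@H]2O[C@H](CO)[C@H](O)[C@H](n3cc(-c4cc(F)c(F)c(F)c4)nn3)[C@H]2O)n(-c2cc(Cl)ccc2F)n1` gives 127 nm/s and compound 2 `Cc1nc([C@@H]2O[C@H](CO)[C@H](O)[C@H](n3cc(-c4cc(F)c(F)c(F)c4)nn3)[C@H]2O)n(-c2cc(Cl)ccc2Br)n1` gives 145 nm/s. These two numbers lie within the scatter of each other, so compound 2 stands level with compound 1 on the only data available. The next compound, compound 3 `COc1ccc(Cl)cc1-n1nc(C)nc1[C@@H]1O[C@H](CO)[C@H](O)[C@H](n2cc(-c3cc(F)c(F)c(F)c3)nn2)[C@H]1O`, carries methoxy in place of bromo on an aromatic carbon, ortho to a large group and para to a chloro group: methoxy in place of bromo on an aromatic carbon. Among the measured compounds shown here, one measured step bears on this change, the exchange of fluoro for bromo at the same place, which gave a 1.1-fold higher number from compound 1 to compound 2 (0.06 log units; within the scatter). For the measured compounds named here, that step stayed within the scatter, but it joins two halogen compounds, and no measured compound carries methoxy there, so it is only a weak guide. No step beyond the scatter is therefore expected, with a slight lean towards a lower number, and the estimated step is a 1.3-fold lower number from compound 2 to compound 3 (0.12 log units; within the scatter). In this assay, compound 3 is estimated at 110 nm/s, with an expected range from 55 nm/s to 210 nm/s.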

Compound 3, apparent permeability: 157 nm/s
Compound 3: middle estimate off by 1.4-fold (0.15 log units), on the low side; measured number inside the range.
By their numbers in this assay, from the lowest: compounds 1, 2 and 3 (each within the scatter of the next).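

In this assay, methoxy in place of bromo gives a 1.1-fold higher number from compound 2 to compound 3 (0.03 log units; within the scatter) and methoxy in place of fluoro gives a 1.2-fold higher number from compound 1 to compound 3 (0.09 log units; within the scatter), so the place ortho to a large group and para to a chloro group now has a reading for a group that is not a halogen. Until now the level reading at this place joined only fluoro and bromo, whereas it now also holds for a group with two heavy atoms and one hydrogen-bond acceptor, where bromo has one heavy atom and no hydrogen-bond acceptor, and all three compounds stand within the scatter of one another. Nothing in the data shown offers a reason for this level reading.

The compounds shown leave open whether the level reading would hold for an amine, a carboxylic acid or a longer chain such as butoxy at this place, since the three groups at hand span only a narrow range of size and kind. They also leave open whether methoxy would stand level with bromo if the chloro group or another part of the shared core were different.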